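Replacing the 2,4-dichlorophenyl group of compound 3

The compounds below may be only part of what the source reports. "The series", "measured", "known", "first", "only" and "open" are said of these compounds alone.

Measured in a functional assay on SW-620 cells (Homo sapiens); a lower number here means a stronger inhibitor of growth, a higher number a weaker inhibitor of growth:
compound 1 `O=S(=O)(/C=C/c1ccc(F)cc1)Cc1ccc(Nc2ncnc3ccccc23)cc1` gives 100000 nM
compound 2 `O=S(=O)(/C=C/c1ccc(Cl)c(Cl)c1)Cc1ccc(Nc2ncnc3ccccc23)cc1` gives 41000 nM
compound 3 `O=S(=O)(/C=C/c1ccc(Cl)cc1Cl)Cc1ccc(Nc2ncnc3ccccc23)cc1` gives 14000 nM

Compound 3 has the lowest number of the three, and its steps to both others lie beyond the scatter. The step followed here leads to compound 4 `O=S(=O)(/C=C/c1ccc(C(F)(F)F)cc1F)Cc1ccc(Nc2ncnc3ccccc23)cc1`, where 2-fluoro-4-(trifluoromethyl)phenyl takes the place of 2,4-dichlorophenyl on a double-bonded chain carbon bound to a double-bonded chain carbon (2-fluoro-4-(trifluoromethyl)phenyl in place of 2,4-dichlorophenyl on a double-bonded chain carbon bound to a double-bonded chain carbon).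

Three measured steps change this same group, and all are modest: (a 2.4-fold lower number from compound 1 to compound 2 (0.39 log units; beyond the scatter)), (a 7.1-fold lower number from compound 1 to compound 3 (0.85 log units; beyond the scatter)) and (a 2.9-fold lower number from compound 2 to compound 3 (0.47 log units; beyond the scatter)). Among the compounds with values here, none of the measured compounds carries a trifluoromethyl group, so the data do not test the incoming group directly. Compound 3 sits lowest, so leaving its group is expected to bring a modest move to a higher number, no larger than the widest step seen (a 7.1-fold lower number from compound 1 to compound 3 (0.85 log units; beyond the scatter)). The expected step in this assay is (a 1.8-fold higher number from compound 3 to compound 4 (0.25 log units; within the scatter)). For compound 4 the estimated value is 25000 nM, with an expected range from 9000 nM to 70000 nM.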

Compound 4, concentration for 50% growth inhibition: 100000 nM
Beside the measured number, compound 4's estimate is 4.0-fold (0.60 log units) below it; measured number outside the range, above it.
By their numbers in this assay, from the lowest: compound 3; then compound 2; then compounds 1 and 4 (each within the scatter of the next).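

In this assay, the 2-fluoro-4-(trifluoromethyl)phenyl group loses the whole lead held by the 2,4-dichlorophenyl group (a 7.1-fold higher number from compound 3 to compound 4 (0.85 log units; beyond the scatter)) and also falls behind the 3,4-dichlorophenyl group (a 2.4-fold higher number from compound 2 to compound 4 (0.39 log units; beyond the scatter)), while it cannot be told apart from the 4-fluorophenyl group (no change at the digits printed from compound 1 to compound 4 (within the scatter)). Across these four compounds, the two dichlorophenyl groups therefore give the lower numbers and the two fluorine-bearing groups the higher ones, and no compound shown goes against this split. No measurement at hand accounts for that split.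

The compounds shown leave open whether chlorine itself is enough, as a phenyl group carrying a single chlorine, or a 2,4-difluorophenyl group, would show. They also leave open how a methoxy, nitrile or amine group would fare on this double-bonded chain carbon.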